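Methoxy step on the sulfonamide ring: carrying over to compound 4

This account rests on a few compounds, and the source may have more. Where it says the series, first, only, none or still open, it means among the compounds named here.

Measured so far in an ADME assay:
compound 1, `O=[N+]([O-])c1cccc(NS(=O)(=O)c2ccccc2)c1`: 7.93
compound 2, `COc1ccc(S(=O)(=O)Nc2cccc([N+](=O)[O-])c2)cc1`: 8.44
compound 3, `O=S(=O)(Nc1ccc(F)cc1)c1ccccc1`: 8.85

Compound 1 and compound 2 differ by one change, (methoxy in place of hydrogen on an aromatic carbon), and that change made a step of a number 0.51 log units higher from compound 1 to compound 2 (beyond the scatter). Compound 3 sits highest of the three measured values; how its core differs from the core of compound 1 is not broken down here. Compound 4, `COc1ccc(S(=O)(=O)Nc2ccc(F)cc2)cc1`, is not yet measured and differs from compound 3 by methoxy in place of hydrogen on an aromatic carbon, the same change as from compound 1 to compound 2, at the same kind of place. Within the data shown here, a step of a number 0.50 log units higher from compound 3 to compound 4 (beyond the scatter) is expected in this assay, close to the earlier one, because the single measured instance a number 0.51 log units higher from compound 1 to compound 2 (beyond the scatter) is the only guide, with one pair only. Compound 4 is therefore estimated at 9.35, with a range of 9 to 9.7 expected.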

Compound 4, acid dissociation constant: 9.32
Estimate against measurement, compound 4: 0.03 log units above, and the stated range covers the measured number.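

In this assay, methoxy in place of hydrogen on an aromatic carbon gives a number 0.47 log units higher from compound 3 to compound 4 (beyond the scatter). Set beside the earlier step, the change carries over between these two cores with no difference that can be told apart: the same change on two cores in this assay, a number 0.51 log units higher (beyond the scatter) from compound 1 to compound 2 and a number 0.47 log units higher (beyond the scatter) from compound 3 to compound 4, 0.04 log units apart, within the scatter of two such steps. Among these compounds, with only two pairs, this holds for these two cores alone; it does not show that the step would keep its size on any other core, and it gives no reason for the step.

Still open, from the compounds shown here alone, is whether an amine, a carboxylic acid or a longer chain such as ethoxy in the same place would give a similar step. Also open, going by these compounds, is how methoxy behaves on a core carrying neither nitro nor fluoro.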